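The source may hold more compounds than are shown below. What is called first, only, known or untested is meant among the compounds shown, and "the series" means these compounds.

For the measured compounds named here, compound 2 `CCC(C)CN[C@H](c1cc(C(F)(F)F)ccc1N1CCN(C(=O)CCc2ccc(Cl)cc2Cl)CC1)C(C)CC` is one of two compounds measured in an assay on HEK293 cells for displacement of a labelled ligand from Melanocortin receptor 4 (Homo sapiens) (a lower number here means a stronger inhibitor, a higher number a weaker inhibitor), and in that assay compound 2 gives 2800 nM. That is the higher of the two numbers, but the other compound, compound 1 `CC(C)C[C@H](N)c1cc(C(F)(F)F)ccc1N1CCN(C(=O)CCc2csc3ccccc23)CC1`, gives 2300 nM in this assay, a gap that falls within the scatter of repeated measurements, so the two cannot be told apart. Compound 3 `CCC(C)[C@H](NC(=O)CN)c1cc(C(F)(F)F)ccc1N1CCN(C(=O)CCc2ccc(Cl)cc2Cl)CC1` has not yet been measured. The change from compound 2 to compound 3 is (aminomethyl)carbonyl in place of 2-methylbutyl on an amine nitrogen, on an amine nitrogen whose other neighbours are a saturated chain carbon. Going by the values given here, no measured pair shows this change, so nothing here says how it acts. The step this estimate means, a 1.4-fold lower number from compound 2 to compound 3 (0.15 log units; within the scatter), is expected to be small, in no fixed direction, and likely within the scatter. Compound 3 is therefore expected to give about 2000 nM in this assay, with a range from 500 nM to 8000 nM.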

Compound 3, inhibition constant: 18 nM
Compound 3: the middle estimate sits 110-fold (2.05 log units) above what was measured; the measured number lies below the stated range.
By their numbers in this assay, from the lowest: compound 3; then compounds 1 and 2 (each within the scatter of the next).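

In this assay, replacing the 2-methylbutyl group with the (aminomethyl)carbonyl group, at an amine nitrogen whose other neighbours are a saturated chain carbon, gives a 160-fold lower number from compound 2 to compound 3 (2.19 log units; beyond the scatter) and shows that the group on this nitrogen can strongly shift the measured number. The earlier compounds shown here could not show this, as no measured pair differed at this place. Nothing shown explains why the step is so large.

This single step cannot say whether the carbonyl, the terminal amine or the loss of the 2-methylbutyl chain accounts for the change. An acetyl group, a longer chain ending in an amine or a chain ending in a carboxylic acid at the same nitrogen would begin to separate these parts.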